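The compounds below may be only part of what the source reports. "The series", "measured", "known", "first", "only" and "open" are said of these compounds alone.

Compound 1 `Nc1ccc(CNC(=O)Nc2ccc(CN3C(=O)c4ccccc4C3=O)cc2)cn1` - 57 nM
Compound 2 `O=C(NCc1cccnc1)Nc1ccc(CN2C(=O)c3ccccc3C2=O)cc1` - "not determined" (no result reported)

In a functional assay on COR-L23 cells (Homo sapiens) for antiproliferative activity, read by CellTiter-Glo, with a stated time of 4 days (a higher number here means a weaker inhibitor, a lower number a stronger inhibitor), compound 1 gives 57 nM. Among the compounds with values here, that is the only number available, as the entry for compound 2 reads "not determined" (no result reported). Compound 1 therefore cannot yet be ranked against anything, and it serves as the sole reference point.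

Compound 3 `O=C(/C=C/c1cccnc1)Nc1ccc(CN2C(=O)c3ccccc3C2=O)cc1` keeps the core of compound 1 but changes one part: 2-(pyridin-3-yl)ethenyl stands in place of ((6-aminopyridin-3-yl)methyl)amino on a carbonyl carbon (2-(pyridin-3-yl)ethenyl in place of ((6-aminopyridin-3-yl)methyl)amino on a carbonyl carbon). Within the data shown here, no measured pair shows what this exchange does, so any forecast is uncertain. A moderate gain in strength is the tentative expectation, and the expected change is a 3.8-fold lower number from compound 1 to compound 3 (0.58 log units; beyond the scatter). Compound 3 is estimated at 15 nM, with an expected range of 2 nM to 100 nM.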

Compound 3, half-maximal inhibitory concentration: 2000 nM
The estimate for compound 3 lay 130-fold (2.12 log units) below the measured number, outside the stated range (above it).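

Exchanging ((6-aminopyridin-3-yl)methyl)amino for 2-(pyridin-3-yl)ethenyl on a carbonyl carbon gives a 35-fold higher number from compound 1 to compound 3 (1.55 log units; beyond the scatter) in this assay and so shows that the strength of the series depends heavily on the group in this place. Both groups carry a six-membered aromatic ring with one hetero atom, so the presence of such a ring alone does not preserve the strength of compound 1. Nothing available explains this large loss.

Compound 3 differs from compound 1 both in the link to the ring and in the amino group on that ring, and the compounds shown do not separate these two changes. On these data alone, it also remains open how a carboxylic acid or a longer chain on this carbonyl carbon would compare.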